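The compounds below may be only part of what the source reports. "The series", "measured", "known", "first", "only" and "open" are said of these compounds alone.

Measured compounds:
compound 1 `O=S(=O)(Nc1ccc(-c2nc3ccccc3o2)cc1)c1cccs1` — in an ADME assay on HEK293 cells (Homo sapiens) for cytotoxicity, read by resazurin assay, with a stated time of 48 h (a higher number here means that more compound is tolerated, a lower number that less compound is tolerated), compound 1 gives > 100000 nM, a limit of the assay.
compound 2 `O=S(=O)(Nc1ccc2oc(-c3ccccc3)nc2c1)c1ccc(Cl)c(Cl)c1` — compound 2 gives 71000 nM.
compound 3 `COc1ccc(S(=O)(=O)Nc2ccc(-c3nc4ccccc4o3)cc2)cc1` — compound 3 gives > 100000 nM, again a limit.

Compound 1 thus stands at the top of the assay with only a limit, as do most of the values here (the limit of > 100000 nM in this assay, at which 2 of the 3 values shown sit). Compound 4 `O=S(=O)(Nc1ccc(-c2nc3ccccc3o2)cc1)c1ccccc1O` is the next variation on the same sulfonyl sulfur: 2-hydroxyphenyl in place of thiophen-2-yl on a sulfonyl sulfur. Within the data shown here, the one measured step at that position, a step that the two limits leave unreadable from compound 1 to compound 3, runs between two limits and so gives no readable size; compound 2 offers a number but no single-point comparison to compound 1. No step beyond the scatter is therefore expected for compound 4, only a value near the limit. Compound 4 is estimated at 100000 nM, within 40000 nM to 250000 nM. The expected step is a number no higher from compound 1 to compound 4 (the limit leaves the size open).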

Compound 4, half-maximal cytotoxic concentration: > 100000 nM
Compound 4 was reported as a limit; the forecaster's own chance of this, stated with the estimate: 60%; the middle value lies on the limit itself.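

Among these compounds, compound 1, compound 3 and compound 4 all stand at a limit, so no step among them can be read: the limit of > 100000 nM in this assay, at which 3 of the 4 values shown sit. From the compounds shown here alone, how the thiophen-2-yl, 4-methoxyphenyl and 2-hydroxyphenyl groups on the sulfonyl sulfur compare in tolerated concentration stays open.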